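Replacing an Aryl Group with Tert-butoxy on a Shared Core

The source may hold more compounds than are shown below. What is called first, only, known or untested is meant among the compounds shown, and "the series" means these compounds.

Of the compounds shown here, three sharing one core have been measured in a functional assay for inhibition of sodium/hydrogen exchanger (Oryctolagus cuniculus); a higher number here means a weaker inhibitor, a lower number a stronger inhibitor. Compound 1 `Cc1c(C(=O)N=C(N)N)cc(S(C)(=O)=O)c(Cl)c1Cl` gives 29 nM. Among the compounds with values here, compound 2 `Cc1c(C(=O)N=C(N)N)cc(S(C)(=O)=O)c(Cl)c1[N+](=O)[O-]` gives 44 nM, and the only single-change step among them, a 1.5-fold higher number from compound 1 to compound 2 (0.18 log units; within the scatter), shows nothing beyond the scatter. Compound 3 `Cc1cc(-c2ccc(F)cc2)c(S(C)(=O)=O)cc1C(=O)N=C(N)N` gives 36 nM, which places it second highest of the three numbers, yet within the scatter of both compound 1 and compound 2.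

Compound 4 `Cc1cc(OC(C)(C)C)c(S(C)(=O)=O)cc1C(=O)N=C(N)N` is not yet measured in this assay. Its change from compound 3 is tert-butoxy in place of 4-fluorophenyl on an aromatic carbon. Within the data shown here, no measured step involves this exchange; the only measured step, a change of one group for another on the core, stayed within the scatter. On that basis the step of a 1.3-fold higher number from compound 3 to compound 4 (0.10 log units; within the scatter) is expected to be small, with no clear direction, since all three measured numbers sit close together. Compound 4 is therefore estimated at 45 nM, with a range from 15 nM to 150 nM.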

Compound 4, half-maximal inhibitory concentration: 9.4 nM
Compound 4: the middle estimate sits 4.8-fold (0.68 log units) above what was measured, outside the stated range (below it).
By their numbers in this assay, from the lowest: compound 4; then compounds 1, 3 and 2 (each within the scatter of the next).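

Within the data shown here, the position ortho to a methylsulfonyl group and meta to a methyl group responds to what it carries: in this assay, tert-butoxy in place of 4-fluorophenyl gives a 3.8-fold lower number from compound 3 to compound 4 (0.58 log units; beyond the scatter), the first single-change step here to lie beyond the scatter. An aromatic ring at this position is therefore not required for a low number, since tert-butoxy has no ring and still gives a lower number than 4-fluorophenyl. Nothing available here accounts for this step, and no measurement bears on its cause.

From the compounds shown here alone, it remains open whether the step follows from the oxygen, from the branched carbon group or simply from the loss of the ring. Comparing methoxy, tert-butyl or an amine at this same position would begin to separate these possibilities, and whether the step holds on other substitution patterns of the shared core is also unsettled.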